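A few compounds are considered here, and "the series" means these few. Any claim that something is new, unique, unknown or untested is made for them only; others in the source may bear on it.

Compound 1 `CCCC(=O)OCSc1ccccc1C(=O)NCCCC(N)=O` and compound 2 `CCCC(=O)OCSc1ccccc1C(=O)Nc1ccccc1C(N)=O` share a common core and were both tested for tolerance by cells. In an ADME assay on CEM-SS cells (Homo sapiens) for cytotoxicity, read by XTT assay, with a stated time of 6 days (a higher number here means that more compound is tolerated, a lower number that less compound is tolerated), compound 1 gives 56.6 uM, which on paper is the larger of the two numbers shown, while compound 2 gives 50.1 uM; the gap between them is within the scatter of repeated measurements, so the two compounds count as indistinguishable here. Compound 3 `CCCC(=O)OCSc1ccccc1C(=O)NCC(=O)NC` has not yet been measured. It differs from compound 1 in one place: methylcarbamoyl in place of 2-carbamoylethyl on a saturated chain carbon bound to an amide-type nitrogen. No step between two measured compounds is known for a change of this kind, so the shown numbers give no direct guide to its effect. The two measured compounds, although built differently, land in the same region, which suggests that this assay does not react strongly to changes at this position. Compound 3 is therefore expected to give about 50 uM in this assay, with a range from 25 uM to 100 uM. The expected step from compound 1 to compound 3 is a 1.1-fold lower number from compound 1 to compound 3 (0.05 log units; within the scatter), estimated to lie within the scatter rather than beyond it.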

Compound 3, half-maximal toxic concentration: > 100 uM
Compound 3: a limit, no number (the forecaster's own chance of this, stated with the estimate: 10%); middle value at least 2.0-fold (0.30 log units) away from the limit.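

In this assay compound 3 gives > 100 uM, which is a limit of the assay and not a number. Among these compounds, putting methylcarbamoyl in place of 2-carbamoylethyl on a saturated chain carbon bound to an amide-type nitrogen gives an at least 1.7-fold higher number from compound 1 to compound 3 (0.24 log units; that floor lies within the scatter), the first direct reading of a single change at this position: the number does not fall, and it may have risen, although the floor of the step alone does not establish a real difference. The full size of the step cannot be read from this result: the limit of > 100 uM in this assay, at which 1 of the 3 values shown sits.

Whether the position would tolerate an amine, a carboxylic acid or a longer chain in place of methylcarbamoyl stays open in the compounds shown. Among the compounds shown here, with only one step at this position, and that step resting on a limit, nothing here separates the effect of one part of the change from another when 3-carbamoylpropyl gives way to (methylcarbamoyl)methyl, or shows whether the same change would read alike on another core.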